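Ester to Acid on an Orexin Receptor Ligand Series

The source may report more compounds than this note shows. Statements on the series, on what has been measured and on what is new or still open speak of the compounds shown alone.

Compound 1 `COC(=O)c1cccc2c(C(=O)c3ccccc3)cc(C(=O)c3ccc(C(F)(F)F)cc3)c-2c1` was tested in an assay on cells for displacement of a labelled ligand from Orexin receptor type 2 (Homo sapiens), read by scintillation counting, with stated times of 10 min and 90 min, tested at 10 uM (on this read-out higher numbers stand for more inhibition at the one concentration tested (going by the name of the read-out) and lower numbers for less inhibition), where compound 1 gives 27%. Its nearest measured neighbour is compound 2 `COC(=O)c1cccc2c(C(=O)c3ccccc3)cc(C(=O)c3ccc(C(Cl)(Cl)Cl)cc3)c-2c1`, which in this assay gives 27%. Within the data shown here, the one measured step, trichloromethyl in place of trifluoromethyl on an aromatic carbon, shows no change at the digits printed from compound 1 to compound 2 (within the scatter), so compound 1 stands level with compound 2 on these numbers.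

Compound 3 `O=C(O)c1cccc2c(C(=O)c3ccccc3)cc(C(=O)c3ccc(C(F)(F)F)cc3)c-2c1` is the compound still to be measured. It differs from compound 1 in one place: hydrogen in place of methyl on an oxygen next to a carbonyl group. Among the measured compounds shown here, no measured step in this set touches that part of the molecule, so the step from compound 1 to compound 2 offers no direct guide, and the expectation rests on the small size of the change. The expected step from compound 1 to compound 3 is no change at the digits printed from compound 1 to compound 3 (within the scatter), none beyond the scatter. Compound 3 is therefore expected to give about 27% in this assay, within a range from 5% to 50%.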

Compound 3, a percentage reported as inhibition, at one concentration (the size of the read-out at that concentration, not a potency): 26.4%
The estimate for compound 3 lay 0.6 percentage points above the measured number; low and high end bracket the measured number.
By their numbers in this assay, from the lowest: compounds 3, 1 and 2 (each within the scatter of the next).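

Going from methoxycarbonyl to carboxy gives a number 0.6 percentage points lower from compound 1 to compound 3 (within the scatter) in this assay, and this is the first reading at this site. The earlier pair differed only at the trifluoromethyl end of the molecule, whereas this step shows that replacing the methyl on this oxygen with hydrogen leaves the inhibition at the one tested concentration within the usual scatter. No separate measurement is available to explain this result.

The compounds shown leave open how other groups would read at this site, such as a primary amide or an ethyl ester in place of the methoxycarbonyl. On these data alone, the carboxy group appears here only with trifluoromethyl, so whether the same step would read alike with trichloromethyl also stays open.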